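The compounds below may be only part of what the source reports. "The series", "measured", "known", "first", "only" and "open" are said of these compounds alone.

The shared core of this series is shown by compound 1 `CC(C)[C@@H]1CC[C@@H](C)C[C@@]12N(C)C(=O)[C@@H]1[C@H]3C(=O)NC(=O)[C@H]3ON12`, in which the amide-type nitrogen of the five-membered ring carries only a hydrogen. In a functional assay, read by spectrophotometry, with a stated time of 2 h, tested at 2.5 mg/mL (a higher number here means a stronger effect of the compound at the concentration tested, a lower number a weaker effect), compound 1 gives 70%. Compound 2 `CC(C)[C@@H]1CC[C@@H](C)C[C@@]12N(C)C(=O)[C@@H]1[C@H]3C(=O)N(c4ccc(Cl)cc4)C(=O)[C@H]3ON12` places a 4-chlorophenyl on that nitrogen, and in this assay compound 2 gives 60.1%, the step being a number 9.9 percentage points lower from compound 1 to compound 2 (within the scatter). Compound 3 `Cc1cccc(N2C(=O)[C@H]3[C@H](ON4[C@@H]3C(=O)N(C)[C@@]43C[C@H](C)CC[C@H]3C(C)C)C2=O)c1` carries a 3-methylphenyl there instead, and in this assay compound 3 gives 47.7%, the lowest of the three numbers, reached by a number 22.3 percentage points lower from compound 1 to compound 3 (beyond the scatter) and by a number 12.4 percentage points lower from compound 2 to compound 3 (beyond the scatter).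

Compound 4 `Cc1ccc(N2C(=O)[C@H]3[C@H](ON4[C@@H]3C(=O)N(C)[C@@]43C[C@H](C)CC[C@H]3C(C)C)C2=O)c(C)c1` differs from compound 3 in one place: 2,4-dimethylphenyl in place of 3-methylphenyl on an amide-type nitrogen in a ring. Going by the values given here, the measured steps that bear on this change are the two that put an aryl group on the ring nitrogen, a number 9.9 percentage points lower from compound 1 to compound 2 (within the scatter) and a number 22.3 percentage points lower from compound 1 to compound 3 (beyond the scatter), and the one that exchanges one aryl group for another, a number 12.4 percentage points lower from compound 2 to compound 3 (beyond the scatter). The aryl-to-aryl exchange gave a modest loss, the others ranged from within the scatter to modest. Among the compounds with values here, no measured step shows what adding a second methyl to such a ring does. The expected step is therefore a number 2.7 percentage points lower from compound 3 to compound 4 (within the scatter), small and within the scatter. Compound 4 is estimated to give 45%, with a range from 30% to 60%.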

Compound 4, a percentage reported as activity, at one concentration (the size of the read-out at that concentration, not a potency): 82.6%
Estimate against measurement, compound 4: 37.6 percentage points below; the whole stated range lies below it.
By their numbers in this assay, from the lowest: compound 3; then compounds 2 and 1 (each within the scatter of the next); then compound 4.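

Going by these compounds alone, compound 4 is the first case where an aryl group on this amide-type nitrogen lifts the read-out beyond the scatter relative to the bare hydrogen of compound 1, a number 12.6 percentage points higher from compound 1 to compound 4 (beyond the scatter), so such a group need not cost activity in this assay. Within the data shown here, the position also proves far more sensitive to the choice of aryl group than the earlier compounds suggested: the step of a number 34.9 percentage points higher from compound 3 to compound 4 (beyond the scatter) is large, although 2,4-dimethylphenyl has only one more carbon than 3-methylphenyl, and the exchange for 4-chlorophenyl also gives a clear gain, a number 22.5 percentage points higher from compound 2 to compound 4 (beyond the scatter). No measurement here accounts for why these closely related groups part so widely.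

Among these compounds, with 3-methylphenyl as the only single-methyl group, it remains open whether the rise belongs to one methyl of the 2,4-dimethylphenyl, to the pair, or to their placement on the ring. It is also unknown how this nitrogen would respond to a group of another kind, such as a benzyl, a longer alkyl chain, or a phenyl bearing an amine or a carboxylic acid, and a read-out at one concentration cannot give the potency of any of these compounds.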